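This account rests on a few compounds, and the source may have more. Where it says the series, first, only, none or still open, it means among the compounds named here.

Measured compounds:
compound 1 `Clc1ncnc2ncn(Cc3ccccc3)c12` — 0%
compound 2 `Fc1ccc(Cn2cnc3ncnc(Cl)c32)cc1` — 8%
compound 3 `c1ccc(Cc2[nH]cnc3ncnc2-3)cc1` — 2%

All three values come from an assay on isolated protein for inhibition of Ca2+/calmodulin-dependent protein kinase II (CaM kinase II) (Rattus norvegicus), tested at 30 uM; on this read-out lower numbers stand for less inhibition and higher numbers for more inhibition at the one concentration tested (going by the name of the read-out). Among the measured compounds shown here, the three numbers sit close together, and no compound is set apart from the others on this read-out. Compound 1 and compound 2 differ in one place: fluoro in place of hydrogen on an aromatic carbon. This change made a step of a number 8 percentage points higher from compound 1 to compound 2 (within the scatter). Compound 1 and compound 3 carry different cores; the difference between the two cores is not broken down here, and their two values are simply what compound 1 and compound 3 each show in this assay.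

Compound 4 `Fc1ccc(Cc2[nH]cnc3ncnc2-3)cc1` has not yet been measured in this assay. It differs from compound 3 by fluoro in place of hydrogen on an aromatic carbon, which is the same change, at the same kind of place, as from compound 1 to compound 2. For the measured compounds named here, because the earlier instance gave a number 8 percentage points higher from compound 1 to compound 2 (within the scatter), a step of about the same size, a number 5 percentage points higher from compound 3 to compound 4 (within the scatter), is expected here, with the single pair of compound 1 and compound 2 as the only basis. Compound 4 is therefore estimated at 7%, expected to fall between -5% and 19%.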

Compound 4, a percentage reported as inhibition, at one concentration (the size of the read-out at that concentration, not a potency): 8%
Beside the measured number, compound 4's estimate is 1 percentage points below it, within the range that was stated.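

In this assay, fluoro in place of hydrogen on an aromatic carbon gives a number 6 percentage points higher from compound 3 to compound 4 (within the scatter), and the two instances of the change do not differ: the same change on two cores in this assay, a number 8 percentage points higher (within the scatter) from compound 1 to compound 2 and a number 6 percentage points higher (within the scatter) from compound 3 to compound 4, 2 percentage points apart, within the scatter of two such steps. Within this one pair of cores, the change therefore carries over with a step of matching size, and nothing separates its outcome on the core of compound 3 from its outcome on the core of compound 1. This does not show that fluoro has a real effect on either core, since each step lies within the scatter, and two cores with small steps at a single concentration give no basis for a rule across the wider series.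

The compounds shown leave open whether an amine, a carboxylic acid or a methoxy group on the six-membered aromatic ring would move the number in this assay beyond the scatter. They also leave open whether a longer chain carrying that ring would do so on either core.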